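Replacing isopropyl with a hexynyl chain in cytotoxicity

The source may hold more compounds than are shown below. What is called first, only, known or untested is meant among the compounds shown, and "the series" means these compounds.

Compound 1 `CCCCC#Cc1c(C)[nH]c2ccc(Cl)cc2c1=O`: > 36300 nM, a limit of the assay
Compound 2 `CCc1c(C)[nH]c2cc(OC)c(Cl)cc2c1=O`: 19000 nM
Compound 3 `COc1cc2[nH]c(C)c(C(C)C)c(=O)c2cc1Cl`: 21700 nM

These values come from an ADME assay on J774 cells (Mus musculus) for cytotoxicity; on this read-out lower numbers stand for an effect already at smaller amounts and higher numbers for an effect only at larger amounts of compound. Compound 3, at 21700 nM, lies within the scatter of compound 2, at 19000 nM. Compound 4 `CCCCC#Cc1c(C)[nH]c2cc(OC)c(Cl)cc2c1=O` differs from compound 3 by hex-1-yn-1-yl in place of isopropyl on an aromatic carbon. Among the measured compounds shown here, the only measured step, a 1.1-fold higher number from compound 2 to compound 3 (0.06 log units; within the scatter), is a smaller change and stays within the scatter. Compound 1 also carries hex-1-yn-1-yl, and its > 36300 nM is a limit. In this assay a slightly higher number is therefore expected, an estimated 1.4-fold higher number from compound 3 to compound 4 (0.14 log units; within the scatter), not clearly beyond the scatter. Compound 4 is estimated at 30000 nM, with an expected range of 15000 nM to 60000 nM.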

Compound 4, half-maximal effective concentration: 15000 nM
The estimate for compound 4 lay 2.0-fold (0.30 log units) above the measured number; low and high end bracket the measured number.
By their numbers in this assay, from the lowest: compounds 4, 2 and 3 (each within the scatter of the next). At a limit, above all of these: compound 1.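

At this aromatic carbon, the chain length and the triple bond of hex-1-yn-1-yl make no readable difference in this assay: there is a 1.4-fold lower number from compound 3 to compound 4 (0.16 log units; within the scatter), and a 1.3-fold lower number from compound 2 to compound 4 (0.10 log units; within the scatter). Among the compounds shown here, with hex-1-yn-1-yl held in place, methoxy in place of hydrogen gives an at least 2.4-fold lower number from compound 1 to compound 4 (0.38 log units; beyond the scatter), the only step here beyond the scatter. Compound 1 stands at a limit, so this step has no fixed size: the limit of > 36300 nM in this assay, at which 1 of the 4 values shown sits. Going by these compounds, whether an amine or a carboxylic acid at the end of the chain would change the number stays open. So does whether methoxy gives a similar step when isopropyl or ethyl occupies this position.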